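From 1H-pyrazol-3-yl to 1H-imidazol-1-yl in the series

The compounds below may be only part of what the source reports. "The series", "measured", "known", "first", "only" and "open" are said of these compounds alone.

In a functional assay on MCF7 cells (Homo sapiens) for antiproliferative activity, read by CellTiter-Glo, with a stated time of 5 days (on this read-out lower numbers stand for stronger inhibition and higher numbers for weaker inhibition), compound 1 (`CC/C(=C(/c1ccc(/C=C/C(=O)O)cc1)c1ccc(-c2cscn2)cc1)c1ccccc1`) gives 120 nM and compound 2 (`CC/C(=C(/c1ccc(/C=C/C(=O)O)cc1)c1ccc(-c2cncs2)cc1)c1ccccc1`) gives 31 nM while compound 3 (`CC/C(=C(/c1ccc(/C=C/C(=O)O)cc1)c1ccc(-c2cc[nH]n2)cc1)c1ccccc1`) gives 440 nM as the highest number of the three. Compound 4 (`CC/C(=C(/c1ccc(/C=C/C(=O)O)cc1)c1ccc(-n2ccnc2)cc1)c1ccccc1`) carries 1H-imidazol-1-yl in place of 1H-pyrazol-3-yl on an aromatic carbon. The measured swaps of this five-membered ring run from modest to large: a 3.9-fold lower number from compound 1 to compound 2 (0.59 log units; beyond the scatter) and a 3.7-fold higher number from compound 1 to compound 3 (0.56 log units; beyond the scatter) and also a 14-fold higher number from compound 2 to compound 3 (1.15 log units; beyond the scatter) as the widest. Among the compounds with values here, no measured compound carries 1H-imidazol-1-yl, so the working expectation is only a move from the top of the span toward compound 1 at 120 nM in this assay as a modest step. The expected step is a 2.6-fold lower number from compound 3 to compound 4 (0.41 log units; beyond the scatter) in this read-out. Compound 4 is estimated at 170 nM (expected range 45 nM to 600 nM).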

Compound 4, half-maximal inhibitory concentration: 380 nM
Estimate against measurement, compound 4: 2.2-fold (0.35 log units) below, within the range that was stated.
By their numbers in this assay, from the lowest: compound 2; then compound 1; then compounds 4 and 3 (each within the scatter of the next).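

In this assay, 1H-imidazol-1-yl in place of 1H-pyrazol-3-yl gives a 1.2-fold lower number from compound 3 to compound 4 (0.06 log units; within the scatter), so at this position, para to a large group, the two rings with two nitrogens cannot be told apart, although only 1H-pyrazol-3-yl carries a hydrogen-bond donor. The thiazoles keep their lead over the new ring, with a 3.2-fold higher number from compound 1 to compound 4 (0.50 log units; beyond the scatter) and a 12-fold higher number from compound 2 to compound 4 (1.09 log units; beyond the scatter). No evidence is available to explain these differences.

Open, going by these compounds, is whether an oxazole or a thiophene here would fall with compound 2 or with compound 4.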